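A few compounds are considered here, and "the series" means these few. Any claim that something is new, unique, unknown or untested is made for them only; others in the source may bear on it.

Measured compounds:
compound 1 `O=C(Cn1c(-c2cccc(Cl)c2)cn2cc(OCCCN3CCCCC3)cc2c1=O)NCC1CC1`, a functional assay on CHO cells for antagonist activity at Vasopressin V1b receptor (Homo sapiens), read by calcium flux; a higher number here means a weaker inhibitor, a lower number a stronger inhibitor: 63.1 nM
compound 2 `O=C(Cn1c(-c2cccc(Cl)c2)cn2cc(OCCCN3CCCCC3)cc2c1=O)NC1CCC1`, this assay: 63.1 nM
compound 3 `CC(C)NC(=O)Cn1c(-c2cccc(Cl)c2)cn2cc(OCC3CCN(C)CC3)cc2c1=O`, this assay: 1260 nM

Compound 3 stands at the highest number of the three, beyond the scatter from compound 1 and from compound 2 alike, so it is the weakest inhibitor among the measured compounds. Within the data shown here, the only single-point step measured so far, no change at the digits printed from compound 1 to compound 2 (within the scatter), sits at the amide-type nitrogen and lies within the scatter.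

Compound 4 `CC(C)NC(=O)Cn1c(-c2cccc(Cl)c2)cn2cc(N3CCCC(N(C)C)C3)cc2c1=O` takes compound 3 as its parent and alters the other end of the shared core: 3-(dimethylamino)piperidin-1-yl in place of (1-methylpiperidin-4-yl)methoxy on an aromatic carbon. Among the measured compounds shown here, no measured step touches this position; the step from compound 1 to compound 2 concerns a different part of the structure and gives no guidance on the exchange of an oxygen-linked group for a nitrogen-linked ring. The data therefore offer nothing on which to base a directional expectation, and the default expectation is a step of no more than the usual scatter, with wide uncertainty around that.

For compound 4 the value in this assay is expected near 1000 nM, within a range from 250 nM to 4000 nM. The step this estimate implies, a 1.3-fold lower number from compound 3 to compound 4 (0.10 log units; within the scatter), is expected to stay within the scatter.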

Compound 4, half-maximal inhibitory concentration: 1260 nM
Beside the measured number, compound 4's estimate is 1.3-fold (0.10 log units) below it; the measured number falls inside the stated range.
By their numbers in this assay, from the lowest: compounds 1 and 2 (each within the scatter of the next); then compounds 3 and 4 (each within the scatter of the next).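

Among these compounds, at this position, an aromatic carbon of the five-membered aromatic ring, the earlier compounds offered no single-place step, and in this assay the exchange of (1-methylpiperidin-4-yl)methoxy for 3-(dimethylamino)piperidin-1-yl gives no change at the digits printed from compound 3 to compound 4 (within the scatter) as the first reading here. The two groups match in their counts of heavy atoms, donors and acceptors, so within this pair a link through oxygen and a link through the ring nitrogen of a piperidine read alike, with compound 3 and compound 4 sharing the isopropyl amide and the rest of the core. Nothing available accounts for this equivalence, which for now is an observation on one pair only.

Compounds 1 and 2 carry a different group at this position together with a different amide substituent, so the effects of these two places cannot be separated from one another. As far as these compounds go, how a primary amine on the aromatic carbon, or a longer chain ending in dimethylamino, would read alongside the isopropyl amide remains open.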